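This account rests on a few compounds, and the source may have more. Where it says the series, first, only, none or still open, it means among the compounds named here.

Two amides built on one shared core have been measured in a physicochemical assay for acid dissociation. Compound 1 `CC(C)N1CCC(Oc2ccc3nc(C(=O)N4CCC4)ccc3c2)CC1` gives 9.5 in this assay, and compound 2 `O=C(c1ccc2cc(OCCCN3CCCCC3)ccc2c1)N1CCC(CO)CC1` gives 9.6; the two numbers fall within the usual scatter of each other. Compound 3 `CC(C)N1CCC(Oc2ccc3cc(C(=O)N4CCC(CO)CC4)ccc3c2)CC1` is not yet measured and differs from compound 2 in one place: 1-isopropylpiperidin-4-yl in place of 3-(piperidin-1-yl)propyl on an oxygen on an aromatic ring. For the measured compounds named here, no measured pair shows this change directly. Compound 3 carries the same 1-isopropylpiperidin-4-yl group on the oxygen as compound 1, which gives 9.5 in this assay. On that basis compound 3 is expected to move by a number 0.10 log units lower from compound 2 to compound 3 (within the scatter), nothing beyond the scatter. Compound 3 is estimated at 9.5, between 9.2 and 9.8.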

Compound 3, acid dissociation constant: 9.6
Compound 3: the middle estimate sits 0.10 log units below what was measured; low and high end bracket the measured number.
By their numbers in this assay, from the lowest: compounds 1, 2 and 3 (each within the scatter of the next).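

In this assay, the direct reading of 1-isopropylpiperidin-4-yl in place of 3-(piperidin-1-yl)propyl on an oxygen on an aromatic ring gives no change at the digits printed from compound 2 to compound 3 (within the scatter). The earlier compounds shown here offered no matched pair for this change; here, the two groups do not separate at this position on this amide. Nothing shown bears on why the reading stays level. Still open, as far as these compounds go, is whether a longer chain carrying the piperidine on the same oxygen, or a morpholine in place of the piperidine, would stay within the scatter of compound 2.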